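A Cyclopropylcarbamoyl Ethenyl Chain Replaces the Methylcarbamoyl Ethyl

This account rests on a few compounds, and the source may have more. Where it says the series, first, only, none or still open, it means among the compounds named here.

Compound 2 `CNC(=O)CCc1ccncc1-c1ccc2ccccc2c1` shares its core with compound 1 `O=C(CCc1ccncc1-c1ccc2ccccc2c1)N1CCOCC1`. In an assay on a protein complex for inhibition of CDK8/Cyclin C (Homo sapiens), with a stated time of 1 h (on this read-out higher numbers stand for weaker inhibition and lower numbers for stronger inhibition), compound 2 gives 21.1 nM, the lowest of the two numbers recorded so far, while compound 1 gives 45.5 nM. Among the measured compounds shown here, the single measured step, a 2.2-fold lower number from compound 1 to compound 2 (0.33 log units; beyond the scatter), comes from methylamino in place of morpholin-4-yl on a carbonyl carbon. Compound 3 `O=C(/C=C/c1ccncc1-c1ccc2ccccc2c1)NC1CC1` differs from compound 2 by 2-(cyclopropylcarbamoyl)ethenyl in place of 2-(methylcarbamoyl)ethyl on an aromatic carbon. For the measured compounds named here, no measured step mirrors this change: the step from compound 1 to compound 2 alters only the substituent on the amide nitrogen and leaves the saturated link as it was, whereas here the cyclopropyl group and the ethenyl link enter together. Going by the values given here, since the only guidance, a 2.2-fold lower number from compound 1 to compound 2 (0.33 log units; beyond the scatter), was modest, a number of the same order as before is expected for the new amide, with a step of about a 1.2-fold higher number from compound 2 to compound 3 (0.07 log units; within the scatter) and a wider uncertainty than usual. Compound 3 is therefore estimated at 25 nM, within a range from 8 nM to 70 nM.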

Compound 3, half-maximal inhibitory concentration: 40.1 nM
Compound 3: the middle estimate sits 1.6-fold (0.21 log units) below what was measured; measured number inside the range.
By their numbers in this assay, from the lowest: compounds 2, 3 and 1 (each within the scatter of the next, the first and the last beyond it).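

In this assay, the step of a 1.9-fold higher number from compound 2 to compound 3 (0.28 log units; within the scatter) shows that this aromatic carbon, opposite the ring nitrogen, accepts 2-(cyclopropylcarbamoyl)ethenyl in place of 2-(methylcarbamoyl)ethyl without a change that stands clear of the scatter, even though the entering chain brings a three-membered ring of carbon and a second double bond outside the aromatic rings. Among the compounds shown here, the earlier compounds varied only the group on the amide nitrogen while the saturated link stayed the same, so this is the first sign that the link and the amide substituent can be altered together and still leave the number within the scatter of compound 2. No measurement on hand offers an explanation for this result.

The two alterations enter as one, so the compounds shown leave open what the ethenyl link would give with the methylcarbamoyl group, or the saturated link with the cyclopropylcarbamoyl group. They also leave open how a carboxylic acid, a primary amine or a longer chain ending in a cyclopropylcarbamoyl group would read at this aromatic carbon.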